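This account rests on a few compounds, and the source may have more. Where it says the series, first, only, none or still open, it means among the compounds named here.

Measured so far, in a functional assay on PCO3 cells (Homo sapiens) for cytotoxicity, read by sulforhodamine B assay; on this read-out lower numbers stand for stronger inhibition of growth and higher numbers for weaker inhibition of growth:

- compound 1 `CC1=CC[C@@H]([C@@](C)(O)CCCC(C)(C)NC(=S)N/N=C\c2ccccc2)CC1`: 8470 nM
- compound 2 `CC1=CC[C@@H]([C@@](C)(O)CCCC(C)(C)NC(=S)N/N=C\c2ccc(N(C)C)cc2)CC1`: 13700 nM

Among the compounds with values here, compound 2 stands at the higher of the two numbers in this assay, but its only neighbour, compound 1, is close: the step of a 1.6-fold higher number from compound 1 to compound 2 (0.21 log units; within the scatter) lies within the scatter, so the two compounds cannot be told apart on these data.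

Compound 3 `CC1=CC[C@@H]([C@@](C)(O)CCCC(C)(C)NC(=S)N/N=C\c2ccccc2[N+](=O)[O-])CC1` is the unmeasured compound. It differs from compound 2 by 2-nitrophenyl in place of 4-(dimethylamino)phenyl on a carbon with a double bond to nitrogen. Within the data shown here, the one measured step, a 1.6-fold higher number from compound 1 to compound 2 (0.21 log units; within the scatter), shows that swapping a hydrogen for a dimethylamino group on the aromatic ring made no difference beyond the scatter. Nothing measured here speaks to a nitro group, nor to a substituent at this other ring position, so the expectation rests only on that single small step. The step of a 1.4-fold lower number from compound 2 to compound 3 (0.16 log units; within the scatter) is therefore expected to be small, with no firm direction. For compound 3 the estimate is 9500 nM, with a range from 3000 nM to 30000 nM in this assay.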

Compound 3, concentration for 50% growth inhibition: 39900 nM
The estimate for compound 3 lay 4.2-fold (0.62 log units) below the measured number, and the stated range ends below it.
By their numbers in this assay, from the lowest: compounds 1 and 2 (each within the scatter of the next); then compound 3.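

In this assay the aromatic ring on the carbon with a double bond to nitrogen now proves sensitive to what it carries: there is a 4.7-fold higher number from compound 1 to compound 3 (0.67 log units; beyond the scatter) with nitro in place of hydrogen on an aromatic carbon, and a 2.9-fold higher number from compound 2 to compound 3 (0.46 log units; beyond the scatter) with 2-nitrophenyl in place of 4-(dimethylamino)phenyl. Within the data shown here, both steps are modest but lie beyond the scatter, so compound 3 is the weakest of the three at inhibiting growth, and this is the first change in the set that can be told apart from the scatter, as the dimethylamino group could not. Nothing available explains why the nitro group lowers growth inhibition in this way.

The compounds shown cannot separate the effect of the nitro group itself from the effect of its place on the ring, as only one nitro compound appears and its ring position differs from that of the dimethylamino group. They also leave open how the ring would respond to other groups, such as a simple amine, a carboxylic acid or a methoxy group, and so whether the loss is specific to nitro.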